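Series notes: whole-organism activity at one dose

The source may report more compounds than this note shows. Statements on the series, on what has been measured and on what is new or still open speak of the compounds shown alone.

Measured so far:
compound 1 `COc1ccccc1/C=C/C(=O)OC/C=C/c1cc(OC)c(OC)cc1OC`: 100%
compound 2 `COc1cc(OC)c(OC)cc1/C=C/COC(=O)/C=C/c1ccc(Br)cc1`: 100%
compound 3 `COc1cc(OC)c(OC)cc1/C=C/COC(=O)/C=C/c1cccc(Br)c1`: 100%

All three were tested in a functional assay on the whole organism (strain Kunming) with Mus musculus as the target, with a stated time of 0.5 h, at a dose of 300 mg/kg by the intraperitoneal route; a lower number here means a stronger effect, a higher number a weaker effect of the compound at the dose given. Compound 3 stands level with compounds 1 and 2 at the digits given; the steps of no change at the digits printed from compound 1 to compound 2 (within the scatter), no change at the digits printed from compound 1 to compound 3 (within the scatter) and no change at the digits printed from compound 2 to compound 3 (within the scatter) all lie within the scatter, so the read-out has so far not moved with any exchange of the group on a double-bonded chain carbon bound to a double-bonded chain carbon.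

Compound 4 `COc1cc(OC)c(OC)cc1/C=C/COC(=O)/C=C/c1ccc(F)cc1` is not yet measured. It differs from compound 3 as follows: 4-fluorophenyl in place of 3-bromophenyl on a double-bonded chain carbon bound to a double-bonded chain carbon. The measured steps that bear on it are the three exchanges of the same group among compounds 1, 2 and 3, each without change beyond the scatter. Going by the values given here, no step to a fluorine-bearing group has been measured, so the fluorine itself is untested. The expectation is therefore no change beyond the scatter, giving an estimated step of no change at the digits printed from compound 3 to compound 4 (within the scatter). The estimate for compound 4 in this assay is 100%, with a range of 85% to 100%.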

Compound 4, a percentage reported as activity, at one dose (the size of the read-out at that dose, not a potency): 100%
The estimate for compound 4 equals the measured number at the digits printed, within the range that was stated.
By their numbers in this assay, from the lowest: compounds 1, 2, 3 and 4 (each within the scatter of the next).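

In this assay a fluorine-bearing group is now covered at this place, on a double-bonded chain carbon bound to a double-bonded chain carbon: 4-fluorophenyl in place of 3-bromophenyl gives no change at the digits printed from compound 3 to compound 4 (within the scatter) and in place of 2-methoxyphenyl gives no change at the digits printed from compound 1 to compound 4 (within the scatter) in this series. The cleanest comparison is fluoro in place of bromo on an aromatic carbon, which gives no change at the digits printed from compound 2 to compound 4 (within the scatter) and so separates the halogen from the other exchanges. No supporting data accompany this result for interpreting it.

Open, from the compounds shown here alone, is whether a carboxylic acid or an amine on the aromatic ring at this place would shift the read-out of this assay at all. With all four compounds level, the series also offers no lower read-out for judging any group, and the shared core remains unvaried.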